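The compounds below may be only part of what the source reports. "The series", "measured", "known", "first", "only" and "open" are said of these compounds alone.

Measured compounds in a functional assay on HCT-116 cells (Homo sapiens) for antiproliferative activity, read by MTT assay; on this read-out higher numbers stand for weaker inhibition and lower numbers for stronger inhibition:

- Compound 1, `Cc1cccc(/C=N/Nc2ncc3c(n2)n(C2CCCC2)c(=O)c(=O)n3C)c1`: compound 1 gives > 100000 nM, which is a limit of the assay and not a number.
- Compound 2, `Cn1c(=O)c(=O)n(C2CCCC2)c2nc(N/N=C/c3ccc(C(F)(F)F)cc3)ncc21`: compound 2 gives 29000 nM.
- Compound 3, `Cn1c(=O)c(=O)n(C2CCCC2)c2nc(N/N=C/c3cccs3)ncc21`: compound 3 gives 52600 nM.

Compound 1 is the weakest point of reference here, since it sits at the limit of > 100000 nM in this assay, at which 1 of the 3 values shown sits, and so only a limit is known for it. Compound 4, `Cn1c(=O)c(=O)n(C2CCCC2)c2nc(N/N=C/c3ccc(F)cc3Cl)ncc21`, differs from compound 1 in one place: 2-chloro-4-fluorophenyl in place of 3-methylphenyl on a carbon with a double bond to nitrogen. Within the data shown here, two measured steps bear on this change, both of which swap the same 3-methylphenyl for another aromatic group on the carbon with a double bond to nitrogen: an at least 3.4-fold lower number from compound 1 to compound 2 (0.53 log units; beyond the scatter), and an at least 1.9-fold lower number from compound 1 to compound 3 (0.27 log units; that floor lies within the scatter). Both point toward lower numbers, one clearly so and one only within the scatter. A halogen-bearing phenyl resembles the first of these swaps more than the second, so in this assay a modest drop from the limit is expected, roughly an at least 2.5-fold lower number from compound 1 to compound 4 (0.39 log units; beyond the scatter). For compound 4 the estimated value is 40000 nM, with a likely range from 15000 nM to 100000 nM.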

Compound 4, half-maximal inhibitory concentration: 13800 nM
The estimate for compound 4 lay 2.9-fold (0.46 log units) above the measured number; measured number below the stated range.
By their numbers in this assay, from the lowest: compound 4; then compounds 2 and 3 (each within the scatter of the next). At a limit, above all of these: compound 1.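

In this assay, the group on the carbon with a double bond to nitrogen now separates compounds that have measured numbers, which compound 2 and compound 3 could not do, as they lie within the scatter of each other. The 2-chloro-4-fluorophenyl group gives a 3.8-fold lower number from compound 3 to compound 4 (0.58 log units; beyond the scatter) and a 2.1-fold lower number from compound 2 to compound 4 (0.32 log units; beyond the scatter), so compound 4 is the most active of the compounds shown, though these are still modest steps. The step of an at least 7.2-fold lower number from compound 1 to compound 4 (0.86 log units; beyond the scatter) is only a floor, as compound 1 stands at a limit: the limit of > 100000 nM in this assay, at which 1 of the 4 values shown sits.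

The compounds shown do not separate the part played by the chlorine from that of the fluorine in the 2-chloro-4-fluorophenyl group. Also open, from the compounds shown here alone, is how a phenyl carrying an amine or a carboxylic acid would behave at this position.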